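Replacing a propyl chain with a fluorophenyl ring

The source may report more compounds than this note shows. Statements on the series, on what has been measured and on what is new or still open speak of the compounds shown alone.

Measured compounds:
Compound 1, `C=CCOc1ccccc1C1CC(=O)c2ccccc2O1`: 47%
Compound 2, `CCCCOc1ccccc1C1CC(=O)c2ccccc2O1`: 42.5%

Of the compounds shown here, two have been measured in a functional assay on J774.A1 cells (Mus musculus) for inhibition, read by immunoassay, with a stated time of 12 h, tested at 30 uM; a higher number here means more inhibition at the concentration tested (going by the name of the read-out), a lower number less inhibition. Compound 1, `C=CCOc1ccccc1C1CC(=O)c2ccccc2O1`, gives 47%. Compound 2, `CCCCOc1ccccc1C1CC(=O)c2ccccc2O1`, gives 42.5%. The one step between them, a number 4.5 percentage points lower from compound 1 to compound 2 (within the scatter), lies within the scatter, so the two numbers cannot be told apart; compound 2 sits at the same level as compound 1 on the numbers shown.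

Compound 3, `O=C1CC(c2ccccc2OCc2cccc(F)c2)Oc2ccccc21`, is not yet measured. It differs from compound 2 by 3-fluorophenyl in place of propyl on a saturated chain carbon bound to an oxygen on an aromatic ring. For the measured compounds named here, no measured step bears on this kind of change: the only step available, a number 4.5 percentage points lower from compound 1 to compound 2 (within the scatter), exchanges one chain for another at the same place and stays within the scatter, and no aromatic group has been placed there before. With no guide in either direction, the step of a number 1.5 percentage points higher from compound 2 to compound 3 (within the scatter) is expected to remain within the scatter. From the compounds shown here alone, compound 3 is therefore estimated at 44%, with a range from 25% to 63%, the width reflecting that an aromatic ring at this place is untested.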

Compound 3, a percentage reported as inhibition, at one concentration (the size of the read-out at that concentration, not a potency): 92.7%
Compound 3: middle estimate off by 48.7 percentage points, on the low side; measured number outside the range, above it.
By their numbers in this assay, from the lowest: compounds 2 and 1 (each within the scatter of the next); then compound 3.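

In this assay the place on a saturated chain carbon bound to an oxygen on an aromatic ring turns out to respond strongly to what is put there, which the exchange of one chain for another had not revealed. Putting 3-fluorophenyl in place of propyl gives a number 50.2 percentage points higher from compound 2 to compound 3 (beyond the scatter) and putting it in place of vinyl gives a number 45.7 percentage points higher from compound 1 to compound 3 (beyond the scatter) on the same shared core, so the large rise appears from either chain, and the same difference can also be read, one bond further out, as butyl to 3-fluorobenzyl. Nothing available explains why this exchange has so large an effect.

The compounds shown leave open whether the rise belongs to the aromatic ring as such or needs its fluorine, a question that a plain phenyl or a chlorophenyl at this place would address. They also leave open whether a saturated cyclohexyl ring, a pyridine ring or a longer chain carrying an amine would go with a number at the level of compound 3 or at that of compound 1 and compound 2.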